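The compounds below may be only part of what the source reports. "The series", "measured", "known", "first", "only" and "open" are said of these compounds alone.

Measured so far in a physicochemical assay for lipophilicity; a higher number here means a more lipophilic compound, a lower number a more polar compound:
- Compound 1 `CC(C)CN1C(=O)CN(Cc2ccc(-c3ccc(F)c(CN4CCCC(C)C4)n3)cc2)C1=O` gives 3.9
- Compound 2 `CCN1C(=O)CN(Cc2ccc(-c3ccc(F)c(CN4CCCCC4)n3)cc2)C1=O` gives 2.1
- Compound 3 `O=C1CN(Cc2ccc(-c3cccc(CN4CCCCC4)n3)cc2)C(=O)N1C1CC1` gives 1.6

Compound 3 is the lowest of the three, beyond the scatter from both compound 2 and compound 1. Compound 4 `CC(C)N1C(=O)CN(Cc2ccc(-c3cccc(CN4CCCCC4)n3)cc2)C1=O` carries isopropyl in place of cyclopropyl on an amide-type nitrogen in a ring. For the measured compounds named here, no measured pair shows this change on its own. With compound 3 at 1.6 as the anchor, a small rise in this assay is expected, close to the edge of the scatter. The expected move is a number 0.40 log units higher from compound 3 to compound 4 (beyond the scatter) and no larger than a modest step. Compound 4 is estimated at 2 (range 1.7 to 2.4).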

Compound 4, distribution coefficient: 2.2
Beside the measured number, compound 4's estimate is 0.20 log units below it; the range from low to high includes it.
By their numbers in this assay, from the lowest: compound 3; then compounds 2 and 4 (each within the scatter of the next); then compound 1.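

In this assay, replacing cyclopropyl with isopropyl on the amide-type nitrogen gives a number 0.60 log units higher from compound 3 to compound 4 (beyond the scatter). For the compounds shown here, this is the first step that can be read at a single place, and it shows that this position registers the change even though both groups have the same heavy-atom count and only the ring is lost. Nothing measured here explains the step. Still open, as far as these compounds go, is how a longer chain such as butyl, or a chain ending in an amine, would read at this nitrogen in this assay. Also open, from the compounds shown here alone, is whether the same swap gives a similar step on the core of compound 2, which carries fluorine.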